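The compounds below may be only part of what the source reports. "The series", "measured", "known", "first", "only" and "open" are said of these compounds alone.

In a functional assay on K562 cells (Homo sapiens) for cytotoxicity, read by XTT assay, with a stated time of 24 h (on this read-out lower numbers stand for stronger inhibition and higher numbers for weaker inhibition), compound 1 `Cc1ccc(NC(=O)c2ccc(OCCCCn3ccnc3)c(Br)c2)cc1Nc1nccc(-c2cccnc2)n1` gives 12000 nM and compound 2 `Cc1ccc(NC(=O)c2ccc(OCCCCn3ccnc3)cc2)cc1Nc1nccc(-c2cccnc2)n1` gives 49900 nM. Compound 2 therefore holds the higher of the two numbers, which makes it the weaker of this pair, and both values sit far up in the micromolar range. Compound 3 `COc1cc(C(=O)Nc2ccc(C)c(Nc3nccc(-c4cccnc4)n3)c2)ccc1OCCCCn1ccnc1` keeps the whole of compound 2 except for one substitution: methoxy in place of hydrogen on an aromatic carbon. In plain terms, this is methoxy in place of hydrogen on an aromatic carbon, ortho to a 4-(1H-imidazol-1-yl)butoxy group. It is the same carbon that carries bromo in compound 1. For the measured compounds named here, only one measured step bears on this change, and it is modest: hydrogen in place of bromo gave a 4.2-fold higher number from compound 1 to compound 2 (0.62 log units; beyond the scatter). Read backwards, a substituent on that carbon went with a lower number. Methoxy is not bromo, however, and a single pair is thin evidence, so only part of that step is assumed to carry over. The expected change is a 1.9-fold lower number from compound 2 to compound 3 (0.28 log units; within the scatter), a small drop that may not clear the scatter. For compound 3 the estimated value is 26000 nM, with an expected range of 10000 nM to 60000 nM.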

Compound 3, half-maximal inhibitory concentration: 29500 nM
For compound 3 the middle estimate is 1.1-fold (0.05 log units) below the measured one; the range from low to high includes it.
By their numbers in this assay, from the lowest: compound 1; then compounds 3 and 2 (each within the scatter of the next).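

Methoxy in place of hydrogen on this carbon, ortho to a 4-(1H-imidazol-1-yl)butoxy group, gives a 1.7-fold lower number from compound 2 to compound 3 (0.23 log units; within the scatter) in this assay, so this change cannot be told apart from no change at all. Methoxy in place of bromo on the same carbon gives a 2.5-fold higher number from compound 1 to compound 3 (0.39 log units; beyond the scatter), which narrows what the earlier pair suggested: having some substituent on this carbon is not enough for a lower number, since compound 1 with bromo stands clear of both other compounds while compound 3 with methoxy goes against the idea. No supporting measurement is available to say what lies behind this difference between bromo and methoxy.

Still open, from the compounds shown here alone, is whether the lower number belongs to bromo alone or is shared by other groups on this carbon, such as chloro, fluoro, trifluoromethyl or an amine. Also open, going by these compounds, is whether a shorter or longer chain in place of the 4-(1H-imidazol-1-yl)butoxy group would alter how much the substituent on this carbon matters.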